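A Selenium Group Replaces Methylsulfanyl on Compound 1

The source may hold more compounds than are shown below. What is called first, only, known or untested is meant among the compounds shown, and "the series" means these compounds.

Three compounds share a core in which a carbon doubly bonded to nitrogen carries two amide-type nitrogens. Compound 1 `CS/C(=N\C(=O)c1csc([N+](=O)[O-])c1)NC(=O)c1csc([N+](=O)[O-])c1` gives, in an ADME assay on MCF-10A cells (Homo sapiens) for cytotoxicity, read by MTT assay, with a stated time of 72 h (a higher number here means a weaker inhibitor of growth, a lower number a stronger inhibitor of growth), a value of 21400 nM, the lowest of the two numbers available, so among those two it is the stronger inhibitor of growth. Compound 3 `CS/C(=N\C(=O)c1cccs1)NC(=O)c1cccs1` gives 55100 nM in this assay. Compound 2 `O=C(/N=C(/NC(=O)c1cccs1)[Se]Cc1ccccc1)c1cccs1` reaches only the assay limit of > 100000 nM in this assay, so no number is known for it. Among the measured compounds shown here, the one measured step that bears on the question is an at least 1.8-fold lower number from compound 2 to compound 3 (0.25 log units; that floor lies within the scatter), in which the methylsulfanyl group takes the place of the selenium-bearing group. Compound 4 `O=C(/N=C(/NC(=O)c1csc([N+](=O)[O-])c1)[Se]Cc1ccccc1)c1csc([N+](=O)[O-])c1`, not yet measured, carries the reverse of that change relative to compound 1: a group of 8 heavy atoms (7 carbon, 1 selenium; one six-membered aromatic ring of carbon only) in place of a group of 2 heavy atoms (1 carbon, 1 sulfur; no ring), on a carbon with a double bond to nitrogen. Read in reverse, the measured step points toward a higher number for compound 4, with a real chance that it reaches the limit (the limit of > 100000 nM in this assay, at which 1 of the 3 values shown sits). Compound 4 is therefore expected to give about 60000 nM, within a range from 25000 nM to 150000 nM. The step expected is a 2.8-fold higher number from compound 1 to compound 4 (0.45 log units; beyond the scatter).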

Compound 4, concentration for total growth inhibition: 54100 nM
Compound 4: the middle estimate sits 1.1-fold (0.04 log units) above what was measured; the measured number falls inside the stated range.
By their numbers in this assay, from the lowest: compound 1; then compounds 4 and 3 (each within the scatter of the next). At a limit, above all of these: compound 2.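

In this assay, the change from methylsulfanyl to the selenium-bearing group, on a carbon with a double bond to nitrogen, can now be given a size beyond the scatter: a 2.5-fold higher number from compound 1 to compound 4 (0.40 log units; beyond the scatter). The earlier pair gave only a floor within the scatter, and the value of compound 2 is a limit. The change now points the same way on two cores, though whether its size is the same remains unsettled: the same change on two cores in this assay, an at least 1.8-fold lower number (0.25 log units; that floor lies within the scatter) from compound 2 to compound 3 and a 2.5-fold lower number (0.40 log units; beyond the scatter) from compound 4 to compound 1; the limit leaves it open whether they differ

Among the compounds shown, the selenium atom and the aromatic ring always enter together, so which of them goes with the higher number stays open. Also open, going by these compounds, is how a benzylsulfanyl group, with sulfur instead of selenium, or a methylselanyl group, with selenium and no ring, would read at this carbon.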